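This account rests on a few compounds, and the source may have more. Where it says the series, first, only, none or still open, it means among the compounds named here.

Compound 1 `Cc1ccnc(/C(N)=N/NC(=S)N2CCSCC2)c1`: in a functional assay on A-375 cells (Homo sapiens) for cytotoxicity, read by MTT assay, with a stated time of 72 h, tested at 1 uM (on this read-out higher numbers stand for more inhibition of growth at the one concentration tested and lower numbers for less inhibition of growth), compound 1 gives 47.7%.
Compound 2 `N/C(=N\NC(=S)N1CCCCC1)c1ccccn1`: in this assay compound 2 gives 72.5%.

Of these two numbers, compound 2 holds the higher one, and compound 1 sits below it by a gap beyond the usual scatter. The two compounds differ in more than one place, so that gap cannot be read as the effect of a single change. Compound 3 `Cc1ccnc(/C(N)=N/NC(=S)N2CCCCC2)c1` differs from compound 2 by methyl in place of hydrogen on an aromatic carbon. Among the compounds with values here, no measured pair shows this change on its own, so its effect is open: a step of moderate size in either direction, or none beyond the scatter, is possible in this assay. Compound 3 is expected to give 62% in this assay, within 42% to 80%. The estimated step is a number 10.5 percentage points lower from compound 2 to compound 3 (beyond the scatter).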

Compound 3, percent growth inhibition at one concentration: 33.5%
For compound 3 the middle estimate is 28.5 percentage points above the measured one; measured number outside the range, below it.
By their numbers in this assay, from the lowest: compound 3; then compound 1; then compound 2.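

In this assay the step is a number 39 percentage points lower from compound 2 to compound 3 (beyond the scatter) when methyl replaces hydrogen on the aromatic carbon opposite the ring nitrogen, so this position is sensitive to substitution. With that methyl present, the ring on the thiocarbonyl carbon also matters: the step is a number 14.2 percentage points lower from compound 1 to compound 3 (beyond the scatter) for piperidin-1-yl in place of thiomorpholin-4-yl. No measurement shown here accounts for either step. Open, as far as these compounds go, is whether a chlorine atom, a methoxy group or an amine on the same carbon would fare as methyl does. Also open, from the compounds shown here alone, is how morpholin-4-yl would compare on the thiocarbonyl carbon.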